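Branching the chain on the ring nitrogen

A few compounds are considered here, and "the series" means these few. Any claim that something is new, unique, unknown or untested is made for them only; others in the source may bear on it.

Compound 1, `CCCCCCN1CCC(C(=O)Nc2cc(Cl)c(N)cc2OC)CC1`: in a functional assay on the whole organism for antagonist activity, with Mus musculus as the target (on this read-out lower numbers stand for an effect already at smaller amounts and higher numbers for an effect only at larger amounts of compound), compound 1 gives only the assay limit > 10 mg/kg.
Compound 2, `CCCCCN1CCC(C(=O)Nc2cc(Cl)c(N)cc2OC)CC1`: in this assay compound 2 gives only the assay limit > 10 mg/kg.

Compound 2 therefore stands at the assay limit, not at a measured number. Going by the values given here, the only measured step, a step that the two limits leave unreadable from compound 1 to compound 2, stays unreadable because both of its ends sit at the limit of > 10 mg/kg in this assay, at which 2 of the 2 values shown sit. Compound 3 is `CCC(CC)CN1CCC(C(=O)Nc2cc(Cl)c(N)cc2OC)CC1`; it differs from compound 2 by pentan-3-yl in place of butyl on a saturated chain carbon bound to an amine nitrogen in a ring. Among the compounds with values here, no measured step tells how this branching acts, so no direction beyond the scatter is expected, and the step that the limit leaves unreadable from compound 2 to compound 3 is estimated as small. Compound 3 is expected near 20 mg/kg, within 5 mg/kg to 80 mg/kg, most likely again reported only as a limit.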

Compound 3, dose for half-maximal effect: > 10 mg/kg
Compound 3: only a limit was reported (the forecaster's own chance of this, stated with the estimate: 75%); the middle value is on the limit's open side.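

Compound 3 also gives only an assay limit, > 10 mg/kg, so no step among compound 1, compound 2 and compound 3 can be read: the limit of > 10 mg/kg in this assay, at which 3 of the 3 values shown sit.

The compounds shown leave open whether pentyl and 2-ethylbutyl differ at all in this read-out.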